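The compounds below may be only part of what the source reports. "The series", "measured", "known", "first", "only" and "open" are said of these compounds alone.

For the measured compounds named here, in a functional assay on HCT-116 cells (Homo sapiens) for antiproliferative activity, read by MTT assay, with a stated time of 72 h (a higher number here means a weaker inhibitor, a lower number a stronger inhibitor), compound 1 `COc1ccc(/C=C2\S/C(=N\c3ccc(Cl)cc3)N(C)C2=O)cc1` gives 10400 nM, the only actual number so far. Compound 2 `C=CC/N=C1/NCC(=C)S1` reads > 100000 nM, which is a limit of the assay and not a number. Compound 3 `COc1ccc(/C=C2\S/C(=N\c3ccccc3)N(C)C2=O)cc1` keeps the core of compound 1 but carries hydrogen in place of chloro on an aromatic carbon, para to a large group (hydrogen in place of chloro on an aromatic carbon). Going by the values given here, no measured pair tests this change, so the expected step of a 1.4-fold higher number from compound 1 to compound 3 (0.16 log units; within the scatter) in this assay is small, toward weaker inhibition and within the usual scatter. Compound 3 is estimated at 15000 nM, with an expected range from 6000 nM to 40000 nM.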

Compound 3, half-maximal inhibitory concentration: > 100000 nM
Compound 3: only a limit was reported (the forecaster's own chance of this, stated with the estimate: 7%); at least 6.6-fold (0.82 log units) between middle value and limit.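

In this assay, the change from 4-chlorophenyl to phenyl gives an at least 9.6-fold higher number from compound 1 to compound 3 (0.98 log units; beyond the scatter), so the chloro on this aromatic carbon matters for the antiproliferative activity of this core. On these data alone, the value of compound 3 is a limit and not a number, so the step shows only a lower bound and its full size stays unknown: the limit of > 100000 nM in this assay, at which 2 of the 3 values shown sit. As far as these compounds go, whether a fluoro, a methyl, a methoxy or an amine in the same place would restore activity stays open. So does whether the chloro matters equally with other groups on the core.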